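Same Shared Core, One Aromatic Group Exchanged

This account rests on a few compounds, and the source may have more. Where it says the series, first, only, none or still open, it means among the compounds named here.

Measured so far:
compound 1 `O=C(N/N=C\c1cccc(O)c1)Nc1nnc(COc2ccc3ccccc3c2)o1` — 300 mg/kg
compound 2 `O=C(N/N=C(/c1ccccc1)c1ccc(O)cc1)Nc1nnc(COc2ccc3ccccc3c2)o1` — 300 mg/kg
compound 3 `O=C(N/N=C(/c1ccccc1)c1ccc([N+](=O)[O-])cc1)Nc1nnc(COc2ccc3ccccc3c2)o1` — 300 mg/kg

In a functional assay on the whole organism (strain Swiss albino) with Mus musculus as the target, with a stated time of 4 h (on this read-out higher numbers stand for an effect only at larger amounts of compound and lower numbers for an effect already at smaller amounts), compound 1 gives 300 mg/kg, and this sits level, within the scatter, with both compound 2 and compound 3. Compound 4 `COc1ccc(/C=N\NC(=O)Nc2nnc(COc3ccc4ccccc4c3)o2)cc1` is not yet measured and differs from compound 1 in a single place: 4-methoxyphenyl in place of 3-hydroxyphenyl on a carbon with a double bond to nitrogen. Among the measured compounds shown here, the one measured step that bears on such an exchange of a group on an aromatic ring is no change at the digits printed from compound 2 to compound 3 (within the scatter), which stayed within the scatter. For the measured compounds named here, with that as the only guide, the step of no change at the digits printed from compound 1 to compound 4 (within the scatter) is expected to be none beyond the scatter. Compound 4 is therefore estimated at 300 mg/kg, with a likely range from 150 mg/kg to 600 mg/kg.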

Compound 4, minimum effective dose: 300 mg/kg
The estimate for compound 4 equals the measured number at the digits printed; low and high end bracket the measured number.
By their numbers in this assay, from the lowest: compounds 1, 2, 3 and 4 (each within the scatter of the next).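

In this assay, the exchange of 3-hydroxyphenyl for 4-methoxyphenyl gives no change at the digits printed from compound 1 to compound 4 (within the scatter) even though the group that leaves has 1 hydrogen-bond donor and the group that enters has 0 hydrogen-bond donors. So, for this pair, the read-out does not depend on that donor, and this holds on a carbon with a double bond to nitrogen that carries no second phenyl ring. Nothing available explains this outcome.

Going by these compounds, all four compounds sit level, so what would shift the value at this position remains unknown. An amine or a carboxylic acid on the ring, or a longer chain in its place, remains an open test.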